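Replacing the Amide Arm with a Nitrophenyl Group

The source may report more compounds than this note shows. Statements on the series, on what has been measured and on what is new or still open speak of the compounds shown alone.

Of the compounds shown here, three that share one core have been measured in a functional assay on DU-145 cells (Homo sapiens) for inhibition, read by MTT assay, with a stated time of 24 h; on this read-out higher numbers stand for weaker inhibition and lower numbers for stronger inhibition. Compound 1 `CCOC(=O)C1=Cc2ccccc2OC1(OCc1cn(CC(=O)Nc2cccc(Cl)c2)nn1)C(F)(F)F` gives 10100 nM. Compound 2 `CCOC(=O)C1=Cc2ccccc2OC1(OCc1cn(CC(=O)Nc2ccc(C)cc2)nn1)C(F)(F)F` reaches only a limit of the assay, > 150000 nM, and is therefore not a number. Compound 3 `CCOC(=O)C1=Cc2ccccc2OC1(OCc1cn(CC(=O)Nc2ccc(I)cc2Cl)nn1)C(F)(F)F` gives 24400 nM, the highest of the two real numbers, with compound 1 nearest at a 2.4-fold higher number from compound 1 to compound 3 (0.38 log units; beyond the scatter). The other steps show how much the group on the amide nitrogen matters: an at least 14-fold higher number from compound 1 to compound 2 (1.17 log units; beyond the scatter), and an at least 6.1-fold lower number from compound 2 to compound 3 (0.78 log units; beyond the scatter), where compound 2 sits at the limit of > 150000 nM in this assay, at which 1 of the 3 values shown sits.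

Compound 4 `CCOC(=O)C1=Cc2ccccc2OC1(OCc1cn(-c2ccc([N+](=O)[O-])cc2)nn1)C(F)(F)F` differs from compound 3 in a larger way than any of these steps: 4-nitrophenyl in place of ((2-chloro-4-iodophenyl)carbamoyl)methyl on an aromatic nitrogen. Every measured step exchanged one ring on the amide nitrogen while keeping the amide arm; here the whole arm is removed and a ring is attached directly to the five-membered ring. For the measured compounds named here, no measured step therefore bears directly on this change. Only the sensitivity of this assay to the group at that end of the molecule can guide a guess, and it argues for a wide range. Compound 4 is expected to give about 30000 nM, between 5000 nM and 150000 nM, meaning an expected step of a 1.2-fold higher number from compound 3 to compound 4 (0.09 log units; within the scatter).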

Compound 4, half-maximal inhibitory concentration: > 150000 nM
Compound 4: only a limit was reported (the forecaster's own chance of this, stated with the estimate: 30%); middle value at least 5.0-fold (0.69 log units) from the limit.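

Compounds 1 to 3 all kept the amide arm and changed only the ring on its nitrogen, so they could not show what happens when the whole arm goes. In this assay, replacing the arm with a 4-nitrophenyl group directly on the aromatic nitrogen gives an at least 6.1-fold higher number from compound 3 to compound 4 (0.78 log units; beyond the scatter) and an at least 14-fold higher number from compound 1 to compound 4 (1.17 log units; beyond the scatter), so inhibition weakens against both arm-bearing compounds that have real numbers. The step between compound 2 and compound 4 cannot be read, as both values are limits, and compound 2 shows that keeping the arm does not by itself give a real number: the limit of > 150000 nM in this assay, at which 2 of the 4 values shown sit.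

Compound 4 loses the arm and brings in the nitro group in one change, so the compounds shown do not say which of the two matters, or whether both do. As far as these compounds go, it also remains open whether an amine or a carboxylic acid in place of the nitro group, or a longer chain in place of the amide arm, would give a real number in this assay.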